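The compounds below may be only part of what the source reports. "The series", "measured", "known", "first", "only" and "open" are said of these compounds alone.

Measured compounds in a functional assay on A375-C5 cells (Homo sapiens) for inhibition, read by sulforhodamine B assay, with a stated time of 48 h; on this read-out lower numbers stand for stronger inhibition of growth and higher numbers for weaker inhibition of growth:
compound 1, `COC(=O)c1sc2cc(C#Cc3ccc(F)cc3)cnc2c1N`: 48400 nM
compound 2, `COC(=O)c1sc2cc(C#Cc3ccccc3F)cnc2c1N`: > 150000 nM, a limit of the assay rather than a number
compound 3, `COC(=O)c1sc2cc(C#Cc3ccc(N(C)C)cc3)cnc2c1N`: 17700 nM

Compound 2 stands apart from the other two: in this assay it returned only a limit, sitting at the limit of > 150000 nM in this assay, at which 1 of the 3 values shown sits. Compound 4, `COC(=O)c1sc2cc(C#Cc3ccccn3)cnc2c1N`, is not yet measured; it differs from compound 2 by pyridin-2-yl in place of 2-fluorophenyl on a triple-bonded carbon.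

Going by the values given here, two measured steps bear on this. Moving the fluorine from the 4-position to the 2-position gave an at least 3.0-fold higher number from compound 1 to compound 2 (0.49 log units; beyond the scatter), and exchanging fluoro for dimethylamino at the 4-position gave a 2.7-fold lower number from compound 1 to compound 3 (0.44 log units; beyond the scatter). Both show that the ring at the end of the triple bond shifts the read-out by modest amounts, and that the 2-substituted pattern is the unfavourable one. Pyridin-2-yl removes the 2-fluoro substituent but places a ring nitrogen at the same point, so a return toward the range of compound 1 is expected, yet without confidence that a number rather than a limit will result. The expected step is an at least 1.8-fold lower number from compound 2 to compound 4 (0.27 log units; that floor lies within the scatter). Compound 4 is therefore estimated at 80000 nM, within 30000 nM to 200000 nM.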

Compound 4, concentration for 50% growth inhibition: 13900 nM
For compound 4 the middle estimate is 5.8-fold (0.76 log units) above the measured one, outside the stated range (below it).
By their numbers in this assay, from the lowest: compounds 4 and 3 (each within the scatter of the next); then compound 1. At a limit, above all of these: compound 2.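

On the triple-bonded carbon, pyridin-2-yl in place of 2-fluorophenyl gives an at least 10-fold lower number from compound 2 to compound 4 (1.03 log units; beyond the scatter) in this assay, so the weak result of compound 2 does not extend to every ring of this size at this place. Pyridin-2-yl in place of 4-fluorophenyl gives a 3.5-fold lower number from compound 1 to compound 4 (0.54 log units; beyond the scatter), which takes the series beyond the level of compound 1 rather than merely back to it. Compound 2 remains a limit of the assay and not a number, so the full size of the first step stays unfixed: the limit of > 150000 nM in this assay, at which 1 of the 4 values shown sits.

The compounds shown do not separate the gain from the ring nitrogen from the loss of the fluorine, a question that unsubstituted phenyl would address. As far as these compounds go, it also remains open whether pyridin-3-yl or pyridin-4-yl would match pyridin-2-yl on the same carbon.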